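The compounds below may be only part of what the source reports. "The series", "measured", "known", "first", "only" and "open" are said of these compounds alone.

Of the compounds shown here, three of one series have been measured so far. Compound 1 `CN1CCc2nc(C#Cc3ccc(Cl)cc3)ccc2C1=O` carries a methyl on the amide-type nitrogen in the ring and a 4-chlorophenyl on the triple-bonded carbon; in a functional assay on HEK293 cells for negative allosteric modulation of metabotropic glutamate receptor 5 (Homo sapiens), read by FLIPR and calcium flux (on this read-out higher numbers stand for weaker inhibition and lower numbers for stronger inhibition), compound 1 gives 352 nM. Compound 2 `CN1CCc2nc(C#Cc3ccccn3)ccc2C1=O` differs from compound 1 only by pyridin-2-yl in place of 4-chlorophenyl on a triple-bonded carbon; in this assay compound 2 gives 184 nM, and the step is a 1.9-fold lower number from compound 1 to compound 2 (0.28 log units; within the scatter). Compound 3 `CC(C)N1CCc2nc(C#Cc3ccc(Cl)cc3)ccc2C1=O` differs from compound 1 by isopropyl in place of methyl on an amide-type nitrogen in a ring; in this assay compound 3 gives 4230 nM, and the step of a 12-fold higher number from compound 1 to compound 3 (1.08 log units; beyond the scatter) leaves compound 3 with the highest number of the three.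

Compound 4 `CC(C)N1CCc2nc(C#Cc3ccccn3)ccc2C1=O` has not yet been measured. It stands to compound 3 as compound 2 stands to compound 1: the change is pyridin-2-yl in place of 4-chlorophenyl on a triple-bonded carbon, and it occurs twice among these compounds. The place is the same in both pairs, a triple-bonded carbon whose other neighbour is a triple-bonded carbon, so this is the same change made on a different core; the two cores differ by isopropyl in place of methyl on an amide-type nitrogen in a ring.

The expectation for compound 4 rests on compound 1 and compound 2, where the same change made a step of a 1.9-fold lower number from compound 1 to compound 2 (0.28 log units; within the scatter), within the scatter. On that basis the step from compound 3 to compound 4 is expected to be of similar size, a 1.7-fold lower number from compound 3 to compound 4 (0.23 log units; within the scatter). Compound 4 is therefore estimated to give 2500 nM in this assay, with a likely range from 1000 nM to 7000 nM. Whether the second core carries the change the same way, the measurement will show.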

Compound 4, half-maximal inhibitory concentration: 27 nM
The estimate for compound 4 lay 93-fold (1.97 log units) above the measured number, outside the stated range (below it).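

In this assay, pyridin-2-yl in place of 4-chlorophenyl on the triple-bonded carbon gives a 160-fold lower number from compound 3 to compound 4 (2.19 log units; beyond the scatter), so the change does not carry over from the core of compound 1 to the core of compound 3 at the same size: the same change on two cores in this assay, a 1.9-fold lower number (0.28 log units; within the scatter) from compound 1 to compound 2 and a 160-fold lower number (2.19 log units; beyond the scatter) from compound 3 to compound 4, 82-fold (1.91 log units) apart, beyond the scatter of two such steps. The same four compounds, read the other way, show that isopropyl in place of methyl on the amide-type nitrogen in the ring gives a 6.8-fold lower number from compound 2 to compound 4 (0.83 log units; beyond the scatter), and that this step runs opposite in direction to the one seen with 4-chlorophenyl: the same change on two cores in this assay, a 12-fold higher number (1.08 log units; beyond the scatter) from compound 1 to compound 3 and a 6.8-fold lower number (0.83 log units; beyond the scatter) from compound 2 to compound 4, 82-fold (1.91 log units) apart, beyond the scatter of two such steps. These two comparisons are a single finding, that the two changes do not act independently in these compounds, but they rest on one set of four compounds and do not show why the steps differ or whether the same holds for other groups.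

From the compounds shown here alone, it remains open whether ethyl or cyclopropyl on the amide-type nitrogen in the ring would behave like isopropyl alongside pyridin-2-yl. Going by these compounds, it is equally open whether pyrimidin-2-yl or pyridin-3-yl on the triple-bonded carbon would share the large step seen with pyridin-2-yl on the isopropyl core.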